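Phenyl in place of 6-chloropyridin-2-yl: expected cost

A few compounds are considered here, and "the series" means these few. Any claim that something is new, unique, unknown or untested is made for them only; others in the source may bear on it.

Measured so far:
compound 1 `Clc1nc(Cl)nc(NCc2ccc(CNc3nc(Cl)nc(Cl)n3)cc2)n1`: 10 nM
compound 2 `Clc1cccc(NCc2ccc(CNc3ncccn3)cc2)n1`: 1 nM
compound 3 `Fc1ccc(NCc2ccc(CNc3ccc(F)cn3)cc2)nc1`: 100 nM

In an assay on MDA-MB-231 cells for displacement of a labelled ligand from C-X-C chemokine receptor type 4 (Homo sapiens) (a lower number here means that less compound is needed, a higher number that more compound is needed for the effect), compound 2 gives the lowest number of the three; compound 1 stands higher, beyond the scatter, and compound 3 higher still, also beyond the scatter. Compound 4 `c1ccc(NCc2ccc(CNc3ncccn3)cc2)cc1` is not yet measured. Against compound 2 it carries phenyl in place of 6-chloropyridin-2-yl on an amine nitrogen. Within the data shown here, no measured pair isolates this change, so its effect is untested in this set. Removing a ring nitrogen and a chlorine from the best compound is expected to raise the number in this assay by a moderate step, beyond the scatter: a 10-fold higher number from compound 2 to compound 4 (1.00 log units; beyond the scatter). Compound 4 is therefore expected to give about 10 nM, within 2 nM to 80 nM.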

Compound 4, effective concentration (reported as EC, without a stated level of effect): 10 nM
For compound 4 middle estimate and measured number coincide at the digits printed; the range from low to high includes it.
By their numbers in this assay, from the lowest: compound 2; then compounds 1 and 4 (each within the scatter of the next); then compound 3.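

Phenyl in place of 6-chloropyridin-2-yl on an amine nitrogen gives a 10-fold higher number from compound 2 to compound 4 (1.00 log units; beyond the scatter) in this assay, the first reading in the series that isolates one place. The change has a cost, yet compound 4 still gives 10 nM, so the 6-chloropyridin-2-yl group is not indispensable for displacement. No supporting data bear on the origin of this step.

From the compounds shown here alone, the ring nitrogen and the chlorine leave together, so their separate shares stay open. A chlorophenyl or an unsubstituted pyridinyl group on the same amine nitrogen would divide them.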